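The compounds below may be only part of what the source reports. "The series", "measured", "known", "first", "only" and "open" are said of these compounds alone.

Measured so far:

Compound 1, `Cn1c(=O)c(S(=O)(=O)c2ccc(C(=O)O)cc2)cc2cnc(Nc3ccc4[nH]ccc4c3)nc21`: 10000 nM
Compound 2, `Cn1c(=O)c(S(=O)(=O)c2ccccc2)cc2cnc(Nc3ccc4cc[nH]c4c3)nc21`: 10000 nM
Compound 3, `Cn1c(=O)c(S(=O)(=O)c2ccc(F)cc2F)cc2cnc(Nc3ccc4cccc(O)c4n3)nc21`: 5000 nM

All three compounds were tested in a functional assay on DU-145 cells (Homo sapiens) for inhibition, read by trypan blue exclusion, with a stated time of 72 h; a higher number here means a weaker inhibitor, a lower number a stronger inhibitor. Compound 1 gives 10000 nM, the same number at the digits shown as compound 2, and together these two sit at the top of the three numbers. Compound 3 gives 5000 nM, a lower number, but the gap to compound 1 lies within the usual scatter, so the three numbers cannot be told apart with confidence; all of them point to weak inhibition.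

The untested compound is compound 4, `Cn1c(=O)c(S(=O)(=O)c2ccc(F)cc2[N+](=O)[O-])cc2cnc(Nc3ccc4[nH]ccc4c3)nc21`. Its difference from compound 1 is counted as 4-fluoro-2-nitrophenyl in place of 4-carboxyphenyl on a sulfonyl sulfur. For the measured compounds named here, no step between two measured compounds reproduces this change, so there is no measured guide to its effect. Compound 3 carries a fluorine-bearing phenyl on the sulfonyl sulfur and gives a number in the same weak range, which suggests that swapping the 4-carboxyphenyl is unlikely to move the number far. The expected step is a 1.7-fold lower number from compound 1 to compound 4 (0.22 log units; within the scatter), within the scatter. Compound 4 is therefore estimated at 6000 nM, with a range from 1500 nM to 15000 nM.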

Compound 4, half-maximal inhibitory concentration: 1500 nM
Compound 4: the middle estimate sits 4.0-fold (0.60 log units) above what was measured; measured number inside the range.
By their numbers in this assay, from the lowest: compound 4; then compounds 3, 1 and 2 (each within the scatter of the next).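

In this assay the group on the sulfonyl sulfur proves able to move the number: 4-fluoro-2-nitrophenyl in place of 4-carboxyphenyl gives a 6.7-fold lower number from compound 1 to compound 4 (0.82 log units; beyond the scatter) with the rest of the molecule unchanged. The earlier compounds shown here differ from one another in more than one place, so they could not show what this position does on its own. This single change also removes the carboxylic acid and brings in both a fluorine and a nitro group, so the step belongs to the swap as a whole. Nothing measured here accounts for the step.

Going by these compounds, whether the fluorine, the nitro group or the loss of the carboxylic acid matters most remains open. So does how a phenyl carrying an amine or a methyl ester on this sulfonyl sulfur would compare.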